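The compounds below may be only part of what the source reports. "The series", "measured", "known", "first", "only" and "open" are said of these compounds alone.

Three selenium-bearing carbamates have so far been measured in a functional assay on HT-29 cells (Homo sapiens) for cytotoxicity, read by MTT assay, with a stated time of 72 h; on this read-out higher numbers stand for weaker inhibition of growth and lower numbers for stronger inhibition of growth. Compound 1 `CC(C)COC(=O)Nc1ccc([Se]C#N)cc1` gives 31300 nM. Compound 2 `CCCCCCOC(=O)Nc1ccc([Se][Se]c2ccc(NC(=O)OCCCCCC)cc2)cc1` gives 42600 nM, and compound 3 `O=C(Nc1ccc([Se][Se]c2ccc(NC(=O)Oc3ccccc3)cc2)cc1)Oc1ccccc1` gives 41600 nM. Compound 1 has the smallest of the three numbers, but its gaps to compound 3 and to compound 2 both lie within the usual scatter of repeated measurements, so the three compounds cannot be told apart on these data. No two of the measured compounds differ from each other in one place only, so nothing is yet known about how any single structural change moves this read-out.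

Compound 4 `N#C[Se]c1ccc(NC(=O)Oc2ccccc2)cc1` has not yet been measured. It differs from compound 1 by phenyl in place of isobutyl on an oxygen next to a carbonyl group. Within the data shown here, the only related comparison comes from compound 2 and compound 3, which differ from each other in the group on the carbamate oxygen and yet give numbers within the scatter of one another. On that basis the step from compound 1 to compound 4 is expected to be small, a 1.0-fold lower number from compound 1 to compound 4 (0.02 log units; within the scatter), with no direction beyond the scatter. Compound 4 is therefore estimated at 30000 nM, with a range from 12000 nM to 75000 nM.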

Compound 4, concentration for total growth inhibition: 41700 nM
The estimate for compound 4 lay 1.4-fold (0.14 log units) below the measured number, within the range that was stated.
By their numbers in this assay, from the lowest: compounds 1, 3, 4 and 2 (each within the scatter of the next).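

Among these compounds, the step from isobutyl to phenyl on an oxygen next to a carbonyl group is the only single change that can be read in this assay, and it gives a 1.3-fold higher number from compound 1 to compound 4 (0.12 log units; within the scatter). Among the compounds shown here, at this place, therefore, an open chain with no ring and a six-membered aromatic ring of carbon only cannot be told apart on this read-out, a direct result that the earlier compounds, none of which differed in one place only, could not give. No measured property of these compounds bears on this result, so the step stands as an observation without an explanation.

The compounds shown leave open whether a group of another kind on this oxygen, such as a chain ending in an amine or a carboxylic acid, would shift the number beyond the scatter, and whether a longer chain would do so on the core of compound 1. They also leave open what a single change in the selenium-bearing part would do while the group on the carbamate oxygen stays the same.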